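Adding a Methyl to the Phenyl of Compound 2

The source may report more compounds than this note shows. Statements on the series, on what has been measured and on what is new or still open speak of the compounds shown alone.

Compound 1 `COC1=C(C)C(=O)/C(=C(O)/C=C/c2cccs2)C(=O)C1(C)C` measured 4 ug/mL
Compound 2 `CCC1=C(OC)C(CC)(CC)C(=O)C(C(=O)/C=C/c2ccccc2)=C1O` measured 2.8 ug/mL

For the measured compounds named here, both values come from a functional assay on 1A9 cells (Homo sapiens) for cytotoxicity (a higher number here means that more compound is needed for the effect, a lower number that less compound is needed), and are the only numbers available for this small set. Compound 2 gives 2.8 ug/mL and so lies within the usual scatter of compound 1, which gives 4 ug/mL here, and the two cannot be ranked against each other. The next compound to be tested is compound 3 `CCC1=C(OC)C(CC)(CC)C(=O)C(C(=O)/C=C/c2ccc(C)cc2)=C1O` and it keeps the core of compound 2 unchanged apart from one site. The change is methyl in place of hydrogen on an aromatic carbon and amounts to methyl in place of hydrogen on an aromatic carbon, turning phenyl to 4-methylphenyl para to a large group. Going by the values given here, the two measured compounds do not differ in one place only, so the data offer no direct precedent for this change. No step beyond the scatter is therefore expected in this assay and neither direction is favoured. What is expected is a 1.1-fold lower number from compound 2 to compound 3 (0.05 log units; within the scatter) and this estimated step stays within the scatter. For compound 3 the estimated value is 2.5 ug/mL with an expected range from 1 ug/mL to 6 ug/mL as the likely span of the measurement.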

Compound 3, concentration for half-maximal effect: 4.3 ug/mL
The estimate for compound 3 lay 1.7-fold (0.24 log units) below the measured number, and the stated range covers the measured number.
By their numbers in this assay, from the lowest: compounds 2, 1 and 3 (each within the scatter of the next).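

For the compounds shown here, this is the first pair in the set that differs in one place only, with methyl in place of hydrogen on an aromatic carbon, turning phenyl to 4-methylphenyl para to a large group. In this assay this change gives a 1.5-fold higher number from compound 2 to compound 3 (0.19 log units; within the scatter) and so the site carries the added methyl without a step beyond the scatter, which leaves compound 2 and compound 3 unranked against each other. Nothing in hand explains this result or ties it to any property of the methyl group.

From the compounds shown here alone, a single methyl says little about other groups at the same site, so it remains open whether a methoxy, a chlorine, a trifluoromethyl, an amine, a carboxylic acid or a longer chain there would also stay within the scatter or would give a real step in either direction. It is also open whether the same methyl-for-hydrogen change would read alike on the core of compound 1, whose other differences from compound 2 cannot be separated with the compounds shown.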